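Lengthening the Acyl Chain of Compound 2

The compounds below may be only part of what the source reports. "The series", "measured", "known", "first", "only" and "open" are said of these compounds alone.

Within the data shown here, in a functional assay on CHO cells (Cricetulus griseus) for inhibition (on this read-out lower numbers stand for stronger inhibition and higher numbers for weaker inhibition), compound 2 `CCCCCCCCCCCC(=O)N[C@@H](CO)C[C@@H](O)c1ccccc1` gives 70 nM, the only actual number so far. Compound 1 `CCCCCCCCCCCCCCCC(=O)N[C@@H](CO)C[C@@H](O)c1ccccc1` gives > 1000 nM in this assay, which is a limit of the assay and not a number.

Compound 3 `CCCCCCCCCCCCCCC(=O)N[C@@H](CO)C[C@@H](O)c1ccccc1` differs from compound 2 by propyl in place of hydrogen on a saturated chain carbon, ten or more bonds along the chain from a carbonyl carbon.

Among the measured compounds shown here, one measured step bears on this change. It is an at least 14-fold lower number from compound 1 to compound 2 (1.15 log units; beyond the scatter), a large step with hydrogen in place of butyl at that same kind of place. The new change runs the opposite way and adds propyl rather than butyl, so it should undo much of that gain. For the measured compounds named here, the true size of the measured step is unknown, and with only two compounds the course between them is not known either.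

In this assay the expected change is a 6.4-fold higher number from compound 2 to compound 3 (0.81 log units; beyond the scatter), toward weaker inhibition and expected to lie beyond the scatter. For compound 3 the estimated value is 450 nM, with an expected range of 130 nM to 1500 nM.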

Compound 3, half-maximal inhibitory concentration: 90 nM
Compound 3: middle estimate off by 5.0-fold (0.70 log units), on the high side; measured number outside the range, below it.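

In this assay, adding propyl on a saturated chain carbon gives a 1.3-fold higher number from compound 2 to compound 3 (0.11 log units; within the scatter), so this change leaves compound 3 indistinguishable from compound 2. The large loss seen earlier therefore does not build up evenly with each added carbon across these three compounds: with hydrogen in place of methyl at the same kind of place, the listed step is an at least 11-fold lower number from compound 1 to compound 3 (1.04 log units; beyond the scatter), nearly as large as the step for hydrogen in place of butyl. The true size of this step remains unknown because compound 1 stands at a limit of the assay and not at a number: the limit of > 1000 nM in this assay, at which 1 of the 3 values shown sits.

The compounds shown leave open how a shorter chain than that of compound 2 would behave, and whether any chain longer than that of compound 1 would follow it. They also leave open whether the sharp change depends on chain length alone, or whether a terminal hydroxyl, an amine or a carboxylic acid at the end of the chain would shift it.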